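Compound 1 to compound 3 at the assay limit

The source may hold more compounds than are shown below. What is called first, only, known or untested is meant among the compounds shown, and "the series" means these compounds.

Compound 1 `O=C(COc1ccc(C(=O)/C=C/c2ccc(F)c(F)c2)cc1)N[C@H]1CCOC1=O`: > 64000 nM
Compound 2 `O=C(CNc1ccccc1F)N[C@H]1CCOC1=O`: > 64000 nM

In a functional assay on MGC-803 cells (Homo sapiens) for antiproliferative activity, read by MTT assay, with a stated time of 72 h (a lower number here means a stronger inhibitor, a higher number a weaker inhibitor), compound 1 gives > 64000 nM as a limit of the assay, not a number. Compound 2 gives > 64000 nM which is likewise a limit. Going by the values given here, compound 1 thus stands at the limit of > 64000 nM in this assay, at which 2 of the 2 values shown sit, and no step between measured compounds is available.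

Compound 3 `O=C(COc1ccc(C(=O)/C=C/c2cccc(Br)c2)cc1)N[C@H]1CCOC1=O` has not yet been measured. It differs from compound 1 by having 3-bromophenyl in place of 3,4-difluorophenyl on a double-bonded chain carbon bound to a double-bonded chain carbon, counted in full as 3-bromophenyl in place of 3,4-difluorophenyl on a double-bonded chain carbon bound to a double-bonded chain carbon in this comparison.

Compound 1 with its limit of > 64000 nM is the only anchor for the expectation. In this assay no step beyond the usual scatter is expected, and any shift that does appear should be toward a stronger inhibitor. The estimate amounts to an at least 1.0-fold lower number from compound 1 to compound 3 (0.02 log units; that floor lies within the scatter) as the expected step. For compound 3 the expected value is 60000 nM with an estimated range from 20000 nM to 120000 nM and a result that is only a limit remains quite likely.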

Compound 3, half-maximal inhibitory concentration: 11900 nM
For compound 3 the middle estimate is 5.0-fold (0.70 log units) above the measured one; the whole stated range lies above it.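

In this assay, 3-bromophenyl in place of 3,4-difluorophenyl on a double-bonded chain carbon bound to a double-bonded chain carbon gives an at least 5.3-fold lower number from compound 1 to compound 3 (0.73 log units; beyond the scatter), so the group at this place can bring the shared core off the assay limit to a measured number. On these data alone, compound 1 gives > 64000 nM, which is a limit of the assay and not a number, so the step is a floor and its true size stays unknown. Compound 3 is the only compound shown with a measured number, against a background of limits: the limit of > 64000 nM in this assay, at which 2 of the 3 values shown sit.

This single change removes both fluorines and brings in one bromine, so the compounds shown do not tell whether the bromine, the loss of the fluorines, or both together carry the step. They also leave open how other groups at this place would read in this assay, such as 3-chlorophenyl, 3-methoxyphenyl or a phenyl ring carrying an amine, and whether any of these would match or go beyond compound 3.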